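Furan for Pyridine on the Amide Carbonyl

A few compounds are considered here, and "the series" means these few. Any claim that something is new, unique, unknown or untested is made for them only; others in the source may bear on it.

Three compounds have been measured in a functional assay on HEK293 cells for positive allosteric modulation of metabotropic glutamate receptor 5 (Homo sapiens), read by calcium flux; on this read-out lower numbers stand for smaller maximal responses and higher numbers for larger maximal responses:

compound 1, `CCC(=O)N1CCCn2nc(COc3ccccc3)cc21`: 48%
compound 2, `O=C(C1CCCC1)N1CCCn2nc(COc3ccccc3)cc21`: 41%
compound 3, `O=C(c1ccccn1)N1CCCn2nc(COc3ccccc3)cc21`: 44%

Compound 3 stands second highest of the three numbers in this assay. Its nearest neighbour is compound 2, with the step of a number 3 percentage points higher from compound 2 to compound 3 (within the scatter); its furthest is compound 1, with the step of a number 4 percentage points lower from compound 1 to compound 3 (within the scatter). Compound 4, `O=C(c1ccco1)N1CCCn2nc(COc3ccccc3)cc21`, has not yet been measured there. It differs from compound 3 in one place: furan-2-yl in place of pyridin-2-yl on a carbonyl carbon.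

All three measured steps exchange the group on the same carbonyl carbon, and none of them moves this assay beyond the scatter: a number 7 percentage points lower from compound 1 to compound 2 (within the scatter), a number 4 percentage points lower from compound 1 to compound 3 (within the scatter) and a number 3 percentage points higher from compound 2 to compound 3 (within the scatter). An alkyl chain, a carbocycle and a six-membered aromatic ring with one hetero atom all give much the same maximal response. A five-membered aromatic ring with one hetero atom in the same place is therefore expected to behave alike, and no step beyond the scatter is expected, no change at the digits printed from compound 3 to compound 4 (within the scatter). For compound 4 the expected value in this assay is 44%, estimated to lie between 33% and 55%.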

Compound 4, largest response reached (reported as percent of maximum), in percent of the reference or control that the assay uses: < 15%
Compound 4 ended at the assay's limit; the forecaster's own chance of this, stated with the estimate: 0%; middle value at least 29 percentage points away from the limit.
By their numbers in this assay, from the lowest: compounds 2, 3 and 1 (each within the scatter of the next). At a limit, below all of these: compound 4.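

In this assay compound 4 gives < 15%, which is a limit of the assay and not a number: the limit of < 15% in this assay, at which 1 of the 4 values shown sits.

Within the data shown here, the group on this carbonyl carbon is not as free to change as the earlier compounds suggested, since furan-2-yl stands apart from ethyl, cyclopentyl and pyridin-2-yl, with a number at least 29 percentage points lower from compound 3 to compound 4 (beyond the scatter), a number at least 26 percentage points lower from compound 2 to compound 4 (beyond the scatter) and a number at least 33 percentage points lower from compound 1 to compound 4 (beyond the scatter). Pyridin-2-yl and furan-2-yl match in hydrogen-bond donors, hydrogen-bond acceptors and net charge, so that match alone does not preserve the maximal response.

The compounds shown do not tell whether the drop follows the five-membered ring or its oxygen, a question that thiophen-2-yl on the same carbonyl carbon would address. Nor do they show whether a methyl group on the furan ring would restore the response.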